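A few compounds are considered here, and "the series" means these few. Any claim that something is new, unique, unknown or untested is made for them only; others in the source may bear on it.

Measured in an ADME assay on the whole organism (strain CD-1) for metabolic stability, with Mus musculus as the target, at a dose of 3 mg/kg by the intravenous route; on this read-out lower numbers stand for a shorter-lived compound and higher numbers for a longer-lived compound:
- Compound 1 `CN(Cc1ccccc1OCCCCC(C)(C)C(=O)O)C(=O)c1ccc(-c2ccco2)cc1`: 4.6 h
- Compound 2 `C[C@@H](CCCOc1ccccc1CN(C)C(=O)c1ccc(-c2ccco2)cc1)CC(=O)O`: 2 h
- Compound 3 `CN(Cc1ccccc1OCCC/C=C/C(=O)O)C(=O)c1ccc(-c2ccco2)cc1`: 1.9 h

Compound 3 sits at the low end of these numbers, level with its nearest neighbour: the measured step is a 1.1-fold lower number from compound 2 to compound 3 (0.02 log units; within the scatter). The gap to the top of the series is larger, a 2.4-fold lower number from compound 1 to compound 3 (0.38 log units; beyond the scatter).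

Compound 4 `C/C(=C\C(=O)O)CCCOc1ccccc1CN(C)C(=O)c1ccc(-c2ccco2)cc1` differs from compound 3 in one place: 2-carboxy-1-methylethenyl in place of 2-carboxyethenyl on a saturated chain carbon, three bonds along the chain from an oxygen on an aromatic ring. Here 2-carboxy-1-methylethenyl stands in place of 2-carboxyethenyl on a saturated chain carbon, three bonds along the chain from an oxygen on an aromatic ring.

For the measured compounds named here, no measured step makes exactly this change, so the evidence is indirect. Swapping 1-(carboxymethyl)ethyl for 2-carboxyethenyl made no visible difference, as a 1.1-fold lower number from compound 2 to compound 3 (0.02 log units; within the scatter) shows. The two steps beyond the scatter both start from 2-carboxy-2-methylpropyl, a group that compound 4 does not carry, and one of them is a 2.3-fold lower number from compound 1 to compound 2 (0.36 log units; beyond the scatter). These steps give little reason to expect a clear shift in this assay, so any movement should be small and, if anything, slightly upward.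

The expected change is a 1.2-fold higher number from compound 3 to compound 4 (0.08 log units; within the scatter), which is not expected to lie beyond the scatter.

For compound 4 the estimated half-life is 2.3 h, with an expected range of 1.2 h to 4.5 h.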

Compound 4, half-life: 1.6 h
Compound 4: middle estimate off by 1.4-fold (0.16 log units), on the high side, and the stated range covers the measured number.
By their numbers in this assay, from the lowest: compounds 4, 3 and 2 (each within the scatter of the next); then compound 1.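

In this assay, the extra methyl of 2-carboxy-1-methylethenyl, compared with 2-carboxyethenyl, gives no visible shift at this position on the saturated chain carbon (a 1.2-fold lower number from compound 3 to compound 4 (0.07 log units; within the scatter)). The new group also stays level with the saturated 1-(carboxymethyl)ethyl (a 1.3-fold lower number from compound 2 to compound 4 (0.10 log units; within the scatter)), so compounds 2, 3 and 4 now form a group of three that cannot be told apart by half-life, while only compound 1, with 2-carboxy-2-methylpropyl, stands clear of them (a 2.9-fold lower number from compound 1 to compound 4 (0.46 log units; beyond the scatter)). No measurement is available that would explain why this one chain end differs from the other three.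

From the compounds shown here alone, what remains open is whether the longer half-life of compound 1 would survive on a longer chain, or with a single methyl rather than two on the 2-carboxy-2-methylpropyl group. It is also open how a tetrazole or an amide in place of the carboxylic acid would behave at this position, since every compound shown ends in the acid.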